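The source may hold more compounds than are shown below. What is called first, only, known or untested is meant among the compounds shown, and "the series" means these compounds.

Compound 1 `CCOC(=O)CNC(=O)NC1=CS(=O)(=O)O[C@@]12[C@@H](CO[Si](C)(C)C(C)(C)C)O[C@@H](n1cc(C)c(=O)n(C)c1=O)[C@@H]2O[Si](C)(C)C(C)(C)C` gives 13000 nM in a functional assay on HEL cells (Homo sapiens) (on this read-out lower numbers stand for higher toxicity in this test and higher numbers for lower toxicity in this test), the lowest of the two numbers in hand. Compound 3 `Cc1cn([C@@H]2O[C@H](CO[Si](C)(C)C(C)(C)C)[C@@]3(OS(=O)(=O)C=C3NCCC(=O)OCc3ccccc3)[C@H]2O[Si](C)(C)C(C)(C)C)c(=O)n(C)c1=O` gives 200000 nM. Compound 2 `Cc1cn([C@@H]2O[C@H](CO[Si](C)(C)C(C)(C)C)[C@@]3(OS(=O)(=O)C=C3NC(=O)NC(=O)c3ccccc3)[C@H]2O[Si](C)(C)C(C)(C)C)c(=O)n(C)c1=O` reaches only a limit of the assay, >= 200000 nM. Both changes made on the amine nitrogen moved the read-out the same way: an at least 15-fold higher number from compound 1 to compound 2 (1.18 log units; beyond the scatter), whose size rests on (the limit of >= 200000 nM in this assay, at which 1 of the 3 values shown sits), and a 15-fold higher number from compound 1 to compound 3 (1.19 log units; beyond the scatter). Compound 4 `Cc1cn([C@@H]2O[C@H](CO[Si](C)(C)C(C)(C)C)[C@@]3(OS(=O)(=O)C=C3NCC(=O)C(N)=O)[C@H]2O[Si](C)(C)C(C)(C)C)c(=O)n(C)c1=O` alters the same nitrogen: (carbamoylcarbonyl)methyl in place of ((ethoxycarbonyl)methyl)carbamoyl on an amine nitrogen. As the two recorded steps at this position were both large and upward, a comparable rise is expected for this change as well, a 4.6-fold higher number from compound 1 to compound 4 (0.66 log units; beyond the scatter). Compound 4 is therefore estimated at 60000 nM, with a range from 15000 nM to 200000 nM.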

Compound 4, half-maximal cytotoxic concentration: 14500 nM
For compound 4 the middle estimate is 4.1-fold (0.62 log units) above the measured one; the whole stated range lies above it.
By their numbers in this assay, from the lowest: compounds 1 and 4 (each within the scatter of the next); then compound 3.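

In this assay, not every change on this amine nitrogen separates from compound 1: a 1.1-fold higher number from compound 1 to compound 4 (0.05 log units; within the scatter), so (carbamoylcarbonyl)methyl and ((ethoxycarbonyl)methyl)carbamoyl are not told apart. The nitrogen is still sensitive to its substituent, as the large step of a 14-fold lower number from compound 3 to compound 4 (1.14 log units; beyond the scatter) shows. A second large step runs the same way, an at least 13-fold lower number from compound 2 to compound 4 (1.13 log units; beyond the scatter), and its size rests on a limit: the limit of >= 200000 nM in this assay, at which 1 of the 4 values shown sits.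

On these data alone, whether a free carboxylic acid or a terminal amine on this chain would read with compound 1 and compound 4 or with compound 3 stays open.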